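Alpha-Ketoamide in Place of the Ethyl Ester

A few compounds are considered here, and "the series" means these few. Any claim that something is new, unique, unknown or untested is made for them only; others in the source may bear on it.

This account follows a small series of peptidyl inhibitors sharing a common core. In an assay on isolated protein (Oryctolagus cuniculus) for inhibition of Calpain-2 catalytic subunit (Homo sapiens), at pH 8.0 (a lower number here means a stronger inhibitor, a higher number a weaker inhibitor), compound 1 `CCOC(=O)C(=O)C(CC)NC(=O)C(CC(C)C)NC(=O)OCc1ccccc1` gives 400 nM. Against compound 2 `CCOC(=O)C(=O)C(CC)NC(=O)C(CC(C)C)NC(=O)CCc1ccccc1`, which gives 1200 nM, the step reads a 3.0-fold higher number from compound 1 to compound 2 (0.48 log units; beyond the scatter). Against compound 3 `CCCCC(NC(=O)C(CC(C)C)NC(=O)OCc1ccccc1)C(=O)C(=O)OCC`, which gives 180 nM, the step reads a 2.2-fold lower number from compound 1 to compound 3 (0.35 log units; beyond the scatter). Compound 1 thus stands second highest of the three numbers, with compound 3 nearest and compound 2 furthest.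

The step now followed leads from compound 1 to compound 4 `CCC(NC(=O)C(CC(C)C)NC(=O)OCc1ccccc1)C(=O)C(=O)NCC1CCCCC1`, where the change is (cyclohexylmethyl)amino in place of ethoxy on a carbonyl carbon. Neither measured step touches this position: the change to compound 2 sits at the capping group, the change to compound 3 at the side chain, and both were modest. No measured pair shows what replacing the ester by an amide at this carbonyl carbon does, so the direction rests on no shown step. Compound 4 is nevertheless expected to give a lower number, estimated at 60 nM with a range from 15 nM to 250 nM, which would mean a step of a 6.7-fold lower number from compound 1 to compound 4 (0.82 log units; beyond the scatter).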

Compound 4, inhibition constant: 44 nM
Compound 4: middle estimate off by 1.4-fold (0.13 log units), on the high side; the measured number falls inside the stated range.
By their numbers in this assay, from the lowest: compound 4; then compound 3; then compound 1; then compound 2.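

In this assay, the carbonyl carbon carrying ethoxy turns out to be a position where the change matters, since (cyclohexylmethyl)amino in its place gives a 9.1-fold lower number from compound 1 to compound 4 (0.96 log units; beyond the scatter). This step is larger than either of the two seen earlier, a 3.0-fold higher number from compound 1 to compound 2 (0.48 log units; beyond the scatter) at the capping group and a 2.2-fold lower number from compound 1 to compound 3 (0.35 log units; beyond the scatter) at the side chain, so among these compounds the ester position moves the number furthest, and it moves it towards stronger inhibition. The exchange brings in a hydrogen-bond donor and a six-membered non-aromatic ring in a single move, and nothing measured here bears on why the number falls.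

On these data alone, what stays open is how the gain divides between the amide nitrogen and the cyclohexylmethyl group, a question that a smaller ethylamino group or an aromatic benzylamino group on the same carbonyl carbon could begin to separate. Also open, as far as these compounds go, is whether the exchange of ethoxy for (cyclohexylmethyl)amino carries over to the phenethyl cap of compound 2 or the longer side chain of compound 3.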